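Piperidine in Place of a Fluorobenzylamine on the Shared Core

The source may hold more compounds than are shown below. What is called first, only, known or untested is meant among the compounds shown, and "the series" means these compounds.

Compound 1 `CCOC(=O)c1cnc(NC2CCCC2)n2nc(-c3ccco3)nc12`: 34.4 nM
Compound 2 `CCOC(=O)c1cnc(NCC2CCCCC2)n2nc(-c3ccco3)nc12`: 432 nM
Compound 3 `CCOC(=O)c1cnc(NCc2ccc(F)cc2)n2nc(-c3ccco3)nc12`: 932 nM

In an assay on CHO cells for displacement of a labelled ligand from adenosine receptor A1 (Homo sapiens) (on this read-out higher numbers stand for weaker inhibition and lower numbers for stronger inhibition), compound 3 gives the highest number of the three. Its nearest neighbour is compound 2, and the step of a 2.2-fold higher number from compound 2 to compound 3 (0.33 log units; beyond the scatter) is modest. Its furthest neighbour is compound 1, and the step of a 27-fold higher number from compound 1 to compound 3 (1.43 log units; beyond the scatter) is large.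

Compound 4 `CCOC(=O)c1cnc(N2CCCCC2)n2nc(-c3ccco3)nc12` differs from compound 3 by piperidin-1-yl in place of (4-fluorobenzyl)amino on an aromatic carbon. Among the measured compounds shown here, two measured steps bear on this change. The step of a 13-fold higher number from compound 1 to compound 2 (1.10 log units; beyond the scatter) and the step of a 27-fold higher number from compound 1 to compound 3 (1.43 log units; beyond the scatter) both show that the compact cyclopentyl on the ring nitrogen gives a far lower number than either larger substituent, while a 2.2-fold higher number from compound 2 to compound 3 (0.33 log units; beyond the scatter) shows only a modest gap between the two larger ones. For the measured compounds named here, compound 4 carries a compact saturated ring again, but the hydrogen-bond donor of compound 3 is gone, and no measured pair tells what that loss does. On balance, a lower number than compound 3 is expected for compound 4, well short of compound 1, and with wide uncertainty: the expected step is a 3.7-fold lower number from compound 3 to compound 4 (0.57 log units; beyond the scatter). Compound 4 is therefore estimated at 250 nM, within a range from 40 nM to 1600 nM.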

Compound 4, inhibition constant: 8860 nM
For compound 4 the middle estimate is 35-fold (1.55 log units) below the measured one, outside the stated range (above it).
By their numbers in this assay, from the lowest: compound 1; then compound 2; then compound 3; then compound 4.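

In this assay, the amino groups at this position do not tolerate closure into piperidin-1-yl: the change gives a 9.5-fold higher number from compound 3 to compound 4 (0.98 log units; beyond the scatter), a 21-fold higher number from compound 2 to compound 4 (1.31 log units; beyond the scatter) and a 260-fold higher number from compound 1 to compound 4 (2.41 log units; beyond the scatter), which makes compound 4 the weakest of the four. The earlier compounds shown here suggested that the bulkier groups were the poorer ones, but piperidin-1-yl has fewer heavy atoms than (4-fluorobenzyl)amino and still gives the higher number, so group size alone does not order these four compounds; compound 4 is also the only one of them with no hydrogen-bond donor in the group on this carbon. No measured evidence is available to explain this loss of binding.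

Compound 4 differs from the others both in lacking the amino hydrogen and in having its ring closed through the nitrogen, so the compounds shown do not separate these two changes. On these data alone, a cyclohexylamino group would keep the amino hydrogen with a six-membered ring, while an N-methyl-N-cyclopentylamino group would remove that hydrogen and leave the cyclopentyl ring in place, and the effect of either on this read-out remains open.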